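Working notes on three analogues in a cell growth assay

The source may report more compounds than this note shows. Statements on the series, on what has been measured and on what is new or still open speak of the compounds shown alone.

compound 1 `CCCSc1nc(N/N=C/c2ccccc2Cl)c2nnn(Cc3ccccc3)c2n1`: 6180 nM
compound 2 `C/C(=N\Nc1nc(SCc2ccccc2)nc2c1nnn2Cc1ccccc1)c1ccccc1O`: 1770 nM

In a functional assay on ECa-109 cells (Homo sapiens) for antiproliferative activity, read by MTT assay, with a stated time of 72 h (a higher number here means a weaker inhibitor, a lower number a stronger inhibitor), compound 1 gives 6180 nM, the highest of the two numbers. Compound 2 gives 1770 nM, a lower number, and the gap between the two lies beyond the usual scatter. The two compounds differ in more than one place, so no single change can be read from that gap.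

Compound 3 `CCCSc1nc(N/N=C/c2ccc([N+](=O)[O-])cc2)c2nnn(Cc3ccccc3)c2n1` differs from compound 1 in one place: 4-nitrophenyl in place of 2-chlorophenyl on a carbon with a double bond to nitrogen. Among the compounds with values here, no measured pair isolates this change, so there is no measured step to lean on. With nothing in the data pointing either way, the step is expected to stay within the scatter, in no particular direction.

Compound 3 is therefore estimated to give 5000 nM in this assay, with a range from 1500 nM to 16000 nM. The expected step of a 1.2-fold lower number from compound 1 to compound 3 (0.09 log units; within the scatter) is small and not beyond the scatter.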

Compound 3, half-maximal inhibitory concentration: 6640 nM
Compound 3: the middle estimate sits 1.3-fold (0.12 log units) below what was measured; measured number inside the range.
By their numbers in this assay, from the lowest: compound 2; then compounds 1 and 3 (each within the scatter of the next).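

In this assay, 4-nitrophenyl in place of 2-chlorophenyl on a carbon with a double bond to nitrogen gives a 1.1-fold higher number from compound 1 to compound 3 (0.03 log units; within the scatter), a step within the scatter. Within the data shown here, this is the only measured step at this position, and it shows that this exchange, which brings in two hydrogen-bond acceptors where the 2-chlorophenyl has none, does not move the reading beyond the scatter. No measurement available here bears on the reason for this result.

A single pair cannot show whether the position tolerates change in general, since the two aryl groups differ in both substituent and placement. Still open, from the compounds shown here alone, is how an unsubstituted phenyl, a 4-aminophenyl or a 4-carboxyphenyl at this place would read against compound 1.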